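Swapping the ring on the core of compound 1

The source may report more compounds than this note shows. Statements on the series, on what has been measured and on what is new or still open speak of the compounds shown alone.

Compound 1, with the structure `CN1CCN(c2ccc3c(c2)oc(=O)n3C(=O)NCCCCc2ccccc2)CC1=O`, is the starting point of this comparison. Within the data shown here, in an assay on HEK293 cells for inhibition of acid ceramidase (Homo sapiens), read by fluorescence, with stated times of 10 min and 3 h (on this read-out higher numbers stand for weaker inhibition and lower numbers for stronger inhibition), compound 1 gives 92 nM, the lowest of the three numbers measured so far. Compound 3, `CCOCCNC(=O)n1c(=O)oc2cc(C3CCN(C)CC3)ccc21`, gives 1050 nM in this assay, and compound 2, `CC(C)CNC(=O)n1c(=O)oc2cc(C3CCCN(C)C3)ccc21`, gives 1750 nM; both of these gaps to compound 1 lie beyond the usual scatter, so compound 1 is the strongest inhibitor of the three.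

The untested compound 4, `CC(=O)N1CCC(c2ccc3c(c2)oc(=O)n3C(=O)NCCCCc2ccccc2)CC1`, keeps the carbamate and its chain from compound 1 and changes only one substituent on the shared core: 1-acetylpiperidin-4-yl in place of 4-methyl-3-oxopiperazin-1-yl on an aromatic carbon. Both groups are six-membered non-aromatic rings of roughly the same size, each carrying one double bond outside aromatic rings, and the two rings differ in their hetero atom and acceptor counts as stated above.

Among the measured compounds shown here, no measured pair shows this exact change, so the expected step from compound 1 to compound 4 is small, a 1.6-fold higher number from compound 1 to compound 4 (0.21 log units; within the scatter), likely within the scatter or slightly toward weaker inhibition. Compound 4 is estimated at 150 nM in this assay, with a range from 40 nM to 600 nM.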

Compound 4, half-maximal inhibitory concentration in the acid ceramidase assay: 64 nM
Beside the measured number, compound 4's estimate is 2.3-fold (0.37 log units) above it; low and high end bracket the measured number.
By their numbers in the acid ceramidase assay, from the lowest: compounds 4 and 1 (each within the scatter of the next); then compounds 3 and 2 (each within the scatter of the next).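

In the acid ceramidase assay, the only single-place change among the compounds shown, 1-acetylpiperidin-4-yl in place of 4-methyl-3-oxopiperazin-1-yl on an aromatic carbon, gives a 1.4-fold lower number from compound 1 to compound 4 (0.16 log units; within the scatter), so this position accepts either ring without a change that can be told from the scatter. In a physicochemical assay for solubility, read by HPLC, in phosphate buffer, measured as kinetic solubility, with a stated time of 1 h, at pH 7.4, tested at 250 uM (on this read-out lower numbers stand for lower solubility and higher numbers for higher solubility), compound 1 gives < 1000 nM, which is a limit of the assay. In the physicochemical assay compound 4 gives < 1000 nM, also a limit, and the step in solubility cannot be read because of that shared limit: the limit of < 1000 nM in the physicochemical assay, at which 2 of the 2 values shown sit.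

On these data alone, it remains open whether a carboxylic acid or a free amine on this aromatic carbon would hold the number in the acid ceramidase assay. As far as these compounds go, it is also open whether either ring would fare the same with a chain other than that of compound 1.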